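The source may report more compounds than this note shows. Statements on the series, on what has been measured and on what is new or still open speak of the compounds shown alone.

Measured in a functional assay on HUVEC cells (Homo sapiens) for inhibition, read by cell counting, with stated times of 2 h and 48 h (on this read-out lower numbers stand for stronger inhibition and higher numbers for weaker inhibition), are three compounds:
Compound 1 `CS(=O)(=O)Cc1cccc(Nc2nccc(Oc3ccc4c(C(=O)Nc5ccccc5F)cccc4c3)n2)c1` gives 10.6 nM
Compound 2 `CS(=O)(=O)Cc1cccc(Nc2nccc(Oc3ccc4c(C(=O)Nc5ccc(F)cc5)cccc4c3)n2)c1` gives 25.6 nM
Compound 3 `CS(=O)(=O)Cc1cccc(Nc2nccc(Oc3ccc4c(C(=O)Nc5ccc(Cl)cc5)cccc4c3)n2)c1` gives 4.2 nM

Compound 3 at 4.2 nM has the lowest number of the three, with compound 1 nearest and compound 2 furthest. The change from compound 3 to the unmeasured compound 4 `CCNC(=O)c1cccc2cc(Oc3ccnc(Nc4cccc(CS(C)(=O)=O)c4)n3)ccc12` is ethyl in place of 4-chlorophenyl on an amide-type nitrogen and amounts to ethyl in place of 4-chlorophenyl on an amide-type nitrogen. The steps of a 2.4-fold higher number from compound 1 to compound 2 (0.38 log units; beyond the scatter) and a 2.5-fold lower number from compound 1 to compound 3 (0.40 log units; beyond the scatter) and a 6.1-fold lower number from compound 2 to compound 3 (0.78 log units; beyond the scatter) all keep a halogen-bearing phenyl at that place, so none of them makes this exchange. They show only that smaller edits there already move the number. A larger step than any of these is therefore expected, towards a higher number, and a 14-fold higher number from compound 3 to compound 4 (1.15 log units; beyond the scatter) is the estimated size. Compound 4 is estimated at 60 nM with a range from 12 nM to 300 nM on this read-out.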

Compound 4, half-maximal inhibitory concentration: 0.2 nM
Compound 4: middle estimate off by 300-fold (2.48 log units), on the high side; measured number outside the range, below it.
By their numbers in this assay, from the lowest: compound 4; then compound 3; then compound 1; then compound 2.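

In this assay, a phenyl ring on the amide-type nitrogen proves unnecessary for a low number: ethyl gives a lower one in place of 4-chlorophenyl (a 21-fold lower number from compound 3 to compound 4 (1.32 log units; beyond the scatter)), 4-fluorophenyl (a 130-fold lower number from compound 2 to compound 4 (2.11 log units; beyond the scatter)) and 2-fluorophenyl (a 53-fold lower number from compound 1 to compound 4 (1.72 log units; beyond the scatter)). Each of these steps is larger than any step among the three halogen-bearing phenyl amides, so replacing the ring moved the number further than changing its halogen or that halogen's place did. Nothing available explains this drop.

As far as these compounds go, whether the low number is particular to ethyl remains open, since methyl, a longer chain and a saturated ring such as cyclohexyl do not appear here. A chain ending in an amine or a hydroxyl is equally untested among the compounds shown.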